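Cytotoxicity notes on the cyclopropylidene nucleoside analogue series

This account rests on a few compounds, and the source may have more. Where it says the series, first, only, none or still open, it means among the compounds named here.

Measured compounds, half-maximal cytotoxic concentration in an ADME assay on HFF cells (Homo sapiens) for cytotoxicity, with a stated time of 8 days; on this read-out higher numbers stand for lower toxicity in this test and lower numbers for higher toxicity in this test:
- compound 1, `CN(C)c1nc(N)nc2c1ncn2/C=C1/CC1(CO)CO`: > 300000 nM, a limit of the assay rather than a number.
- compound 2, `Nc1nc(OCc2ccccc2)c2ncn(/C=C3/CC3(CO)CO)c2n1`: > 300000 nM, likewise a limit of the assay.
- compound 3, `CCCCCOc1nc(N)nc2c1ncn2/C=C1/CC1(CO)CO`: 259000 nM.

Compound 1 therefore stands at the top of this assay, at the limit where two of the three values shown sit (the limit of > 300000 nM in this assay, at which 2 of the 3 values shown sit); nothing separates it from compound 2 on these numbers, and its step to compound 3 reads as an at least 1.1-fold lower number from compound 1 to compound 3 (0.06 log units; that floor lies within the scatter), which sits within the usual scatter. The step of an at least 1.1-fold lower number from compound 2 to compound 3 (0.06 log units; that floor lies within the scatter) tells the same story, and a step that the two limits leave unreadable from compound 1 to compound 2.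

The unmeasured compound 4, `CCCOc1nc(N)nc2c1ncn2/C=C1/CC1(CO)CO`, differs from compound 1 as follows: propoxy in place of dimethylamino on an aromatic carbon. Going by the values given here, the only measured step that bears on this exchange is the one to compound 3, where pentyloxy in place of dimethylamino gave an at least 1.1-fold lower number from compound 1 to compound 3 (0.06 log units; that floor lies within the scatter). A propoxy group is the shorter chain of the two, and the one measured alkoxy variant stayed close to the limit, so no step beyond the scatter is expected in this assay, and an outcome reported only as a limit is likely.

Compound 4 is estimated at 300000 nM, with a range of 150000 nM to 600000 nM. The expected step from compound 1 is accordingly a number no higher from compound 1 to compound 4 (the limit leaves the size open), essentially flat.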

Compound 4, half-maximal cytotoxic concentration: > 300000 nM
Compound 4: a limit, no number (the forecaster's own chance of this, stated with the estimate: 60%); the middle value sits exactly at the limit.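

In this assay compound 4 gives > 300000 nM, a limit of the assay and not a number. Shortening pentyloxy to propoxy on this aromatic carbon gives an at least 1.1-fold higher number from compound 3 to compound 4 (0.06 log units; that floor lies within the scatter), so the chain change shows no step beyond the scatter, although the floor leaves the true size of the step open, and the steps from compound 1 and from compound 2 to compound 4 cannot be read. Propoxy thus joins dimethylamino and benzyloxy at the same limit, and an alkoxy group on this carbon is now seen there in two of the three cases, with the pentyloxy of compound 3 as the only measured number: the limit of > 300000 nM in this assay, at which 3 of the 4 values shown sit.

Going by these compounds, how far compound 1, compound 2 and compound 4 lie past the limit stays open, so no order among them can be drawn from this read-out. Also open, on these data alone, is whether a longer chain such as octyloxy, or a cyclic amine such as piperidine, on this aromatic carbon would give a number clearly beyond the scatter from these compounds.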